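Swapping chloro for fluoro on the sulfonyl-phenyl ring

The source may report more compounds than this note shows. Statements on the series, on what has been measured and on what is new or still open speak of the compounds shown alone.

Among the compounds with values here, compound 2 `CC1CCN(c2c(S(=O)(=O)c3ccc(Cl)cc3)cnc3cc(Cl)ccc23)CC1` gives 91% in an assay on isolated protein for displacement of a labelled ligand from metabotropic glutamate receptor 5 (Homo sapiens), with a stated time of 60 min, tested at 1 uM (a lower number here means less inhibition, a higher number more inhibition at the concentration tested (going by the name of the read-out)), the lowest of the two numbers so far, though its nearest neighbour compound 1 `CC1CCN(c2c(S(=O)(=O)c3ccccc3)cnc3cc(Cl)ccc23)CC1` gives 93% within the scatter. Within the data shown here, the only measured step, a number 2 percentage points lower from compound 1 to compound 2 (within the scatter), came from chloro in place of hydrogen and stayed within the scatter. Compound 3 `CC1CCN(c2c(S(=O)(=O)c3ccc(F)cc3)cnc3cc(Cl)ccc23)CC1` differs from compound 2 by fluoro in place of chloro on an aromatic carbon. Among the measured compounds shown here, no step of this kind has been measured, so no shift beyond the scatter is expected: a number 1 percentage points lower from compound 2 to compound 3 (within the scatter) is the estimated change. Compound 3 is expected to give about 90%, between 80% and 97%.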

Compound 3, a percentage reported as inhibition, at one concentration (the size of the read-out at that concentration, not a potency): 91%
For compound 3 the middle estimate is 1 percentage points below the measured one; low and high end bracket the measured number.
By their numbers in this assay, from the lowest: compounds 2, 3 and 1 (each within the scatter of the next).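

In this assay, fluoro in place of chloro gives no change at the digits printed from compound 2 to compound 3 (within the scatter) and fluoro in place of hydrogen gives a number 2 percentage points lower from compound 1 to compound 3 (within the scatter) on the same aromatic carbon. Hydrogen, chloro and fluoro, para to a large group, now all lie within the scatter of one another, extending the single earlier comparison to a second halogen. Nothing available explains why these numbers agree.

Going by these compounds, whether a methoxy group, an amine or a carboxylic acid at this position would move the number beyond the scatter stays open. Readings at one concentration also leave any difference in potency among these compounds unresolved.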